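Working notes: replacing the methoxycarbonyl of compound 2

A few compounds are considered here, and "the series" means these few. Any claim that something is new, unique, unknown or untested is made for them only; others in the source may bear on it.

Compound 1 `CCCCCCCCCC(O)CNC(C)=O`: "not active" (no number reported)
Compound 2 `COC(=O)CCCCCCCCC(O)CN`: 7890 nM

Among the measured compounds shown here, in a functional assay on A549 cells (Homo sapiens) for cytotoxicity, read by MTT assay (a lower number here means a stronger inhibitor, a higher number a weaker inhibitor), compound 2 gives 7890 nM, the only number. Compound 1 has no number to compare with it. Compound 3 `NCC(O)CCCCCCCCCO` differs from compound 2 as follows: hydroxymethyl in place of methoxycarbonyl on a saturated chain carbon, nine bonds along the chain from an oxygen on a saturated carbon. This places hydroxymethyl in place of methoxycarbonyl on a saturated chain carbon, nine bonds along the chain from an oxygen on a saturated carbon. For the measured compounds named here, no measured step gauges this change, so no shift beyond the scatter is expected in this assay. The expected size is a 1.3-fold higher number from compound 2 to compound 3 (0.10 log units; within the scatter). The estimate for compound 3 is 10000 nM, with an expected range of 4000 nM to 30000 nM.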

Compound 3, half-maximal inhibitory concentration: 16200 nM
Compound 3: the middle estimate sits 1.6-fold (0.21 log units) below what was measured, and the stated range covers the measured number.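

In this assay this place, on a saturated chain carbon, nine bonds along the chain from an oxygen on a saturated carbon, now has its first measured step: hydroxymethyl in place of methoxycarbonyl gives a 2.1-fold higher number from compound 2 to compound 3 (0.31 log units; beyond the scatter), a modest change. The number therefore responds to the group at this place, and it stays measurable with hydroxymethyl there. Nothing available explains the shift.

Still open, from the compounds shown here alone, is whether a carboxylic acid or an amine at this place would move the number further. Going by these compounds, whether a longer chain would change it is also open.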